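Swapping the ring on the nitrogen of a pyridazinone core

A few compounds are considered here, and "the series" means these few. Any claim that something is new, unique, unknown or untested is made for them only; others in the source may bear on it.

Compound 2 `O=c1c2ccccc2c(-c2cccnc2)nn1C1CCCC1` gives 97% in an assay on isolated protein (Oryctolagus cuniculus) with Thromboxane-A synthase (Homo sapiens) as the target, tested at 1 uM; a higher number here means more inhibition at the concentration tested (going by the name of the read-out), a lower number less inhibition. For the measured compounds named here, the only other compound measured, compound 1 `CC(C)n1nc(-c2cccnc2)c2ccccc2c1=O`, gives 87%; the step of a number 10 percentage points higher from compound 1 to compound 2 (within the scatter) lies within the scatter, so both sit at the same high level. Compound 3 `O=c1c2ccccc2c(-c2cccnc2)nn1Cc1ccccc1` differs from compound 2 by benzyl in place of cyclopentyl on an aromatic nitrogen. That one measured step, isopropyl to cyclopentyl, bears only loosely on a change to benzyl, and it gave no shift beyond the scatter. Compound 3 is therefore expected to stay high, estimated at 90% with a range from 70% to 99%, an expected step of a number 7 percentage points lower from compound 2 to compound 3 (within the scatter).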

Compound 3, a percentage reported as inhibition, at one concentration (the size of the read-out at that concentration, not a potency): 97%
Beside the measured number, compound 3's estimate is 7 percentage points below it; the measured number falls inside the stated range.
By their numbers in this assay, from the lowest: compounds 1, 2 and 3 (each within the scatter of the next).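

In this assay, the nitrogen substituent can carry an aromatic ring as well as a non-aromatic one with no shift beyond the scatter, whether benzyl replaces cyclopentyl (no change at the digits printed from compound 2 to compound 3 (within the scatter)) or isopropyl (a number 10 percentage points higher from compound 1 to compound 3 (within the scatter)). Benzyl, with seven heavy atoms against five for cyclopentyl, keeps the same high level. Nothing available explains why these groups read alike.

From the compounds shown here alone, whether an amine, a carboxylic acid or a longer chain on this nitrogen would hold that level remains open. Going by these compounds, with all three numbers this high at a single concentration, any difference in potency among them also remains unknown.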